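Ester to acid on two indole-derived cores

A few compounds are considered here, and "the series" means these few. Any claim that something is new, unique, unknown or untested is made for them only; others in the source may bear on it.

Compound 1 `CCOC(=O)C(=O)CC(=O)/C=C/c1cn(Cc2ccccc2)c2ccccc12` and compound 2 `O=C(/C=C/c1cn(Cc2ccccc2)c2ccccc12)CC(=O)C(=O)O` share one core; compound 3 `CCOC(=O)C(=O)CC(=O)/C=C/c1cc(C(=O)c2ccccc2)cn1Cc1ccccc1` and compound 4 `O=C(/C=C/c1cc(C(=O)c2ccccc2)cn1Cc1ccccc1)CC(=O)C(=O)O` share another, and the difference between the two cores is not broken down here. In an ADME assay on HeLa cells (Homo sapiens) for inhibition, read by MTT assay, with a stated time of 48 h (on this read-out higher numbers stand for weaker inhibition and lower numbers for stronger inhibition), compound 1 gives only a limit, > 40000 nM. In this assay compound 2 likewise gives only a limit, > 40000 nM. The change from compound 1 to compound 2 is hydrogen in place of ethyl on an oxygen next to a carbonyl group, and its step that the two limits leave unreadable from compound 1 to compound 2. From compound 3 to compound 4 the change is hydrogen in place of ethyl on an oxygen next to a carbonyl group, the same change at the same place. In this assay compound 3 gives "not determined" (no result reported), so no result was obtained for it. Resting on (the limit of > 40000 nM in this assay, at which 2 of the 3 values shown sit), compound 4 is expected to give 60000 nM in this assay. The expected range for compound 4 runs from 20000 nM to 200000 nM, most likely reported again only as a limit.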

Compound 4, half-maximal inhibitory concentration: > 40000 nM
Compound 4 was reported as a limit; the forecaster's own chance of this, stated with the estimate: 85%; the middle value does not contradict the limit.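

No new step can be read from compound 3 to compound 4: in this assay compound 3 gives "not determined" (no result reported). Compound 4 gives > 40000 nM, which is a limit and not a number. The compounds shown leave open whether hydrogen in place of ethyl shifts inhibition in this assay on either core.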